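From 3-Fluorophenyl to 3,5-Difluorophenyl: A Small Step Expected

The source may report more compounds than this note shows. Statements on the series, on what has been measured and on what is new or still open speak of the compounds shown alone.

In a functional assay on the whole organism for inhibition, with Lemna aequinoctialis as the target, with a stated time of 7 days, tested at 500 ug/mL (on this read-out higher numbers stand for more inhibition of growth at the one concentration tested and lower numbers for less inhibition of growth), compound 1 (`O=C1Nc2ccc(F)cc2/C1=N/NC(=S)Nc1cccc(C(F)(F)F)c1`) gives 30% and compound 2 (`O=C1Nc2ccc(F)cc2/C1=N/NC(=S)Nc1ccccc1F`) gives 35% at the one concentration tested. Compound 3 (`O=C1Nc2ccc(F)cc2/C1=N/NC(=S)Nc1cccc(F)c1`) gives 30% there, which places it level with compound 1 and within the scatter of compound 2.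

Compound 4 (`O=C1Nc2ccc(F)cc2/C1=N/NC(=S)Nc1cc(F)cc(F)c1`) has not yet been measured. It carries fluoro in place of hydrogen on an aromatic carbon, meta to a fluoro group, which turns 3-fluorophenyl into 3,5-difluorophenyl (fluoro in place of hydrogen on an aromatic carbon).

Going by the values given here, no measured step adds a second fluoro, so the two available steps serve only as a guide to size. Putting fluoro in place of trifluoromethyl shows no change at the digits printed from compound 1 to compound 3 (within the scatter) and putting 3-fluorophenyl in place of 2-fluorophenyl shows a number 5 percentage points lower from compound 2 to compound 3 (within the scatter) on the same read-out. Among the compounds with values here, with these steps as the only guide, no change beyond the scatter is expected in this assay in either direction.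

The expected step is no change at the digits printed from compound 3 to compound 4 (within the scatter) and no larger shift is anticipated. Compound 4 is estimated at 30% with an expected range of 20% to 45% in this assay.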

Compound 4, percent growth inhibition at one concentration: 15%
For compound 4 the middle estimate is 15 percentage points above the measured one; the whole stated range lies above it.
By their numbers in this assay, from the lowest: compound 4; then compounds 1, 3 and 2 (each within the scatter of the next).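

In this assay, going by these compounds alone, adding a second fluoro to the 3-fluorophenyl group gives the first step in this set that lies beyond the scatter, with a number 15 percentage points lower from compound 3 to compound 4 (beyond the scatter) as the result, whereas the earlier steps between compounds 1, 2 and 3 all stayed within it. The 3,5-difluorophenyl group also separates from the 2-fluorophenyl group, showing a number 20 percentage points lower from compound 2 to compound 4 (beyond the scatter) on the same read-out. This aromatic carbon, meta to a fluoro group, is therefore a place where one added heavy atom moves the growth inhibition downward, at the one concentration tested.

On these data alone, whether a chloro, a methoxy or an amine on that same carbon would lower the number in the same way stays open. No measurement shown here bears on what lies behind the drop.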